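Ring Size Change on the Core: Cyclopentyl to Cyclohexyl

A few compounds are considered here, and "the series" means these few. Any claim that something is new, unique, unknown or untested is made for them only; others in the source may bear on it.

Measured compounds and their values:
Compound 1, `CC[C@@H]1C(=O)N(C)c2cnc(Nc3ccc(C(=O)NC4CCN(C)CC4)cc3OC)nc2N1C1CCCCC1`, 4 nM
Compound 2, `COc1cc(C(=O)NC2CCN(C)CC2)ccc1Nc1ncc2c(n1)N(C1CCCC1)[C@H](C)C(=O)N2C`, 1.1 nM
Compound 3, `COc1cc(C(=O)NC2CCN(C)CC2)ccc1Nc1ncc2c(n1)N(C1CCCC1)[C@@H](C)C(=O)N2C`, 8.7 nM

All three compounds were tested in an assay on isolated protein for inhibition of serine/threonine-protein kinase PLK1 (Homo sapiens), read by Z'-LYTE; on this read-out lower numbers stand for stronger inhibition and higher numbers for weaker inhibition. Compound 2 has the lowest number of the three; compound 1 sits a little higher and compound 3 higher still. Compound 2 and compound 3 share every atom and bond, and the step of a 7.9-fold higher number from compound 2 to compound 3 (0.90 log units; beyond the scatter) rests on (the fact that compounds 2 and 3 differ only in the configuration as drawn).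

Compound 4, `COc1cc(C(=O)NC2CCN(C)CC2)ccc1Nc1ncc2c(n1)N(C1CCCCC1)[C@H](C)C(=O)N2C`, has not yet been measured. It differs from compound 2 only in cyclohexyl in place of cyclopentyl on a nitrogen on an aromatic ring in a ring. Among the compounds with values here, the only measured step, the one from compound 2 to compound 3, concerns configuration and not ring size, so no step of the kind made here has been seen. Compound 1, which also carries a cyclohexyl group, gives 4 nM, and compound 2 gives 1.1 nM; both numbers are low. Compound 4 is therefore expected to stay in the same region, with the step of a 2.0-fold higher number from compound 2 to compound 4 (0.30 log units; within the scatter) expected to be small. The estimate for compound 4 is 2.2 nM, with a range from 0.8 nM to 6 nM.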

Compound 4, half-maximal inhibitory concentration: 8.6 nM
The estimate for compound 4 lay 3.9-fold (0.59 log units) below the measured number; the measured number lies above the stated range.
By their numbers in this assay, from the lowest: compound 2; then compound 1; then compounds 4 and 3 (each within the scatter of the next).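

In this assay, within the data shown here, the group on a nitrogen on an aromatic ring proves sensitive to ring size: cyclohexyl in place of cyclopentyl gives a 7.8-fold higher number from compound 2 to compound 4 (0.89 log units; beyond the scatter) as the first measured step of this kind. With cyclohexyl held constant, the chain on the neighbouring ring atom also matters, since hydrogen in place of methyl on that chain, which turns ethyl into methyl, gives a 2.2-fold higher number from compound 1 to compound 4 (0.33 log units; beyond the scatter) in the same assay. The earlier compounds shown here could not show either effect, as compound 1 and compound 2 differ in both ring size and chain, so the low number of compound 1 could not be credited to its cyclohexyl group; in this pair of cyclohexyl compounds, the one with ethyl has the lower number.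

Still open, from the compounds shown here alone, is whether ethyl would lower the number with cyclopentyl too, and whether a smaller cyclobutyl or a larger cycloheptyl group would continue the trend seen from cyclopentyl to cyclohexyl. The only explanatory fact available concerns configuration, so it offers nothing on why ring size or chain length changes the number.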